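Compound 4: same atoms, stereocentre drawn without a configuration

This account rests on a few compounds, and the source may have more. Where it says the series, first, only, none or still open, it means among the compounds named here.

In an ADME assay on MT4 cells (Homo sapiens) for cytotoxicity, read by MTT assay, with a stated time of 5 days (on this read-out lower numbers stand for higher toxicity in this test and higher numbers for lower toxicity in this test), compound 3 (`Cc1cc(-c2ccc(C#N)cc2)cc(C)c1[C@H](O)c1ccnc(Nc2ccc(C#N)cc2)n1`) gives 5560 nM and lies within the scatter of both compound 1 (`Cc1cc(-c2ccc(C#N)cc2)ccc1[C@H](O)c1ccnc(Nc2ccc(C#N)cc2)n1`) at 4000 nM and compound 2 (`Cc1cc(-c2ccc(C#N)cc2)ccc1C(O)c1ccnc(Nc2ccc(C#N)cc2)n1`) at 9940 nM on this read-out. Compound 4 (`Cc1cc(-c2ccc(C#N)cc2)cc(C)c1C(O)c1ccnc(Nc2ccc(C#N)cc2)n1`) differs from compound 3 in one respect: the two compounds have the same atoms and bonds; at least one stereo element is drawn with a configuration in one of them and without one in the other: 1 of 1 stereo elements differ; a stereocentre at a saturated chain carbon is drawn S in compound 3 and without a configuration in compound 4 and nothing else. Among the measured compounds shown here, the one measured precedent for this change is a 2.5-fold higher number from compound 1 to compound 2 (0.40 log units; beyond the scatter) and goes with the fact that one of compounds 1 and 2 is drawn with a defined configuration and the other without, at the place where they differ as its only difference. The methyl step, a 1.4-fold higher number from compound 1 to compound 3 (0.14 log units; within the scatter) for comparison, offers no reason to expect a different outcome. A modest move to a higher number is therefore expected, resting on a single precedent. The expected change is a 2.2-fold higher number from compound 3 to compound 4 (0.33 log units; beyond the scatter) in this assay for now. Compound 4 is estimated at 12000 nM with an expected range from 6000 nM to 25000 nM in this series.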

Compound 4, half-maximal cytotoxic concentration: 6050 nM
Estimate against measurement, compound 4: 2.0-fold (0.30 log units) above; low and high end bracket the measured number.
By their numbers in this assay, from the lowest: compounds 1, 3, 4 and 2 (each within the scatter of the next, the first and the last beyond it).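

In this assay, the stereo change gives a 1.1-fold higher number from compound 3 to compound 4 (0.04 log units; within the scatter), so the step seen on the other core, a 2.5-fold higher number from compound 1 to compound 2 (0.40 log units; beyond the scatter), does not recur on the core of compound 3 and is not a general effect of this drawing change. The methyl in place of hydrogen on an aromatic carbon now gives a 1.6-fold lower number from compound 2 to compound 4 (0.22 log units; within the scatter), and its two readings agree within the scatter: the same change on two cores in this assay, a 1.4-fold higher number (0.14 log units; within the scatter) from compound 1 to compound 3 and a 1.6-fold lower number (0.22 log units; within the scatter) from compound 2 to compound 4, 2.3-fold (0.36 log units) apart, within the scatter of two such steps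

Open, from the compounds shown here alone, is how the R configuration at the saturated chain carbon reads in this test. Also open, going by these compounds, is whether an amine or a methoxy group on that aromatic carbon moves the number beyond the scatter.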